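A methyl added to the fused ring of compound 2

The source may hold more compounds than are shown below. What is called first, only, known or untested is meant among the compounds shown, and "the series" means these compounds.

Measured so far:
compound 1, `CCCNc1nc(NCc2ccc(C(=O)N3CCC(C(=O)NCc4ccc(F)cc4)CC3)cc2)c2cc(C)ccc2n1`: 5200 nM in a functional assay on SW480 cells (Homo sapiens) for inhibition, read by luminescence and resazurin assay, with a stated time of 3 days; a higher number here means a weaker inhibitor, a lower number a stronger inhibitor
compound 2, `CN(C)c1nc(NCc2ccc(C(=O)N3CCC(C(=O)NCc4ccc(F)cc4)CC3)cc2)c2ccccc2n1`: 5500 nM in this assay

Compound 2 and compound 1 differ from each other in two places, and their two numbers in this assay lie within the usual scatter of each other, so neither can be called the weaker of the pair. Compound 2 thus stands at the only level of inhibition seen so far, side by side with compound 1.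

Compound 3, `Cc1ccc2nc(N(C)C)nc(NCc3ccc(C(=O)N4CCC(C(=O)NCc5ccc(F)cc5)CC4)cc3)c2c1`, is compound 2 with one change: methyl in place of hydrogen on an aromatic carbon. Compound 1 also carries a methyl on the carbon-only ring of its fused system, and its value sits within the scatter of compound 2, which gives no sign that such a methyl moves the number on its own. For compound 3 no step beyond the scatter is expected in this assay, in either direction, and the estimated step of a 1.1-fold lower number from compound 2 to compound 3 (0.04 log units; within the scatter) reflects this. Compound 3 is therefore estimated at 5000 nM, with a range from 2500 nM to 10000 nM.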

Compound 3, half-maximal inhibitory concentration: 5600 nM
Compound 3: middle estimate off by 1.1-fold (0.05 log units), on the low side, and the stated range covers the measured number.
By their numbers in this assay, from the lowest: compounds 1, 2 and 3 (each within the scatter of the next).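

In this assay the methyl on the carbon-only ring of the fused system can now be read on its own: the step is a 1.0-fold higher number from compound 2 to compound 3 (0.01 log units; within the scatter) and shows that this single added carbon leaves the number within the scatter. With this methyl in place on both compounds, dimethylamino in place of propylamino can also be read by itself, and the step of a 1.1-fold higher number from compound 1 to compound 3 (0.03 log units; within the scatter) likewise stays within the scatter. Nothing measured here offers an explanation for either result.

Going by these compounds, whether methoxy, chlorine or trifluoromethyl at this aromatic carbon would move the number remains open. So does the effect of a primary amine or morpholine in place of dimethylamino, and of a methyl on the other carbons of this ring.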